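The source may hold more compounds than are shown below. What is called first, only, known or untested is meant among the compounds shown, and "the series" means these compounds.

Compound 1 `O=C(Nc1cccc(-c2oc3cc(-c4ccc(F)cc4)ccc3c(=O)c2O)c1)c1ccc(F)cc1F`: 11200 nM
Compound 2 `Cc1cccc(C(=O)Nc2cccc(-c3oc4cc(-c5ccc(F)cc5)ccc4c(=O)c3O)c2)c1`: 2840 nM
Compound 3 `COc1ccc(C(=O)Nc2cccc(-c3oc4cc(-c5ccc(F)cc5)ccc4c(=O)c3O)c2)c(F)c1`: 17600 nM

These three share one core and differ only in the aryl group attached to the amide carbonyl. In a functional assay on MDA-MB-231 cells (Homo sapiens) for antiproliferative activity, read by CCK-8 assay, with a stated time of 72 h (a higher number here means a weaker inhibitor, a lower number a stronger inhibitor), compound 3 gives 17600 nM, the highest number of the three, so it is the weakest measured inhibitor. Against compound 1 it stands close, a 1.6-fold higher number from compound 1 to compound 3 (0.20 log units; within the scatter), whereas the gap to compound 2 is clear, a 6.2-fold higher number from compound 2 to compound 3 (0.79 log units; beyond the scatter).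

Compound 4 `N#Cc1ccc(C(=O)Nc2cccc(-c3oc4cc(-c5ccc(F)cc5)ccc4c(=O)c3O)c2)cc1` carries 4-cyanophenyl in place of 2-fluoro-4-methoxyphenyl on a carbonyl carbon. Among the measured compounds shown here, no measured step exchanges a substituted phenyl for a cyanophenyl, so the bearing of the earlier steps is indirect. They show that the aryl on the carbonyl moves this assay modestly: a 3.9-fold lower number from compound 1 to compound 2 (0.60 log units; beyond the scatter), while a single substituent swap, a 1.6-fold higher number from compound 1 to compound 3 (0.20 log units; within the scatter), stayed within the scatter. Two of the three aryl groups tried gave weak inhibition; only the methylphenyl did better. A modest gain from compound 3 is therefore expected, a 2.2-fold lower number from compound 3 to compound 4 (0.34 log units; beyond the scatter), without reaching compound 2. Compound 4 is estimated at 8000 nM, between 2500 nM and 25000 nM.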

Compound 4, half-maximal inhibitory concentration: 11600 nM
For compound 4 the middle estimate is 1.5-fold (0.16 log units) below the measured one, within the range that was stated.
By their numbers in this assay, from the lowest: compound 2; then compounds 1, 4 and 3 (each within the scatter of the next).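

In this assay, 4-cyanophenyl on the carbonyl carbon cannot be told apart from either 2-fluoro-4-methoxyphenyl or 2,4-difluorophenyl, with a 1.5-fold lower number from compound 3 to compound 4 (0.18 log units; within the scatter) and a 1.0-fold higher number from compound 1 to compound 4 (0.02 log units; within the scatter). So three aryl groups with quite different substituents now sit together at this position, while the 3-methylphenyl group stands clear of the new compound, with a 4.1-fold higher number from compound 2 to compound 4 (0.61 log units; beyond the scatter), which leaves compound 2 as the strongest of the four. Nothing measured here gives a reason for this separation.

The compounds shown leave open whether the methyl group itself matters or its place on the ring, which a comparison with 4-methylphenyl or plain phenyl would address. As far as these compounds go, how an amine, a carboxylic acid or a longer chain on this aryl ring would behave also remains unknown.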